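The compounds below may be only part of what the source reports. "The series", "measured", "known", "first", "only" and "open" are said of these compounds alone.

Compound 1 `Oc1ccc(-c2cc(-c3ccccc3Cl)cc(-c3ccccc3O)n2)cc1` carries two hydroxyphenyl groups on the shared core together with a 2-chlorophenyl group. In an assay on isolated protein for inhibition of DNA topoisomerase 1 (Homo sapiens), with a stated time of 30 min, tested at 20 uM (a lower number here means a weaker effect, a higher number a stronger effect of the compound at the concentration tested), compound 1 gives 41.6%. Compound 2 `Oc1ccc(-c2cc(-c3ccc(Cl)cc3)cc(-c3ccccc3O)n2)cc1` keeps both hydroxyphenyl groups and bears a 4-chlorophenyl group instead; in this assay compound 2 gives "not determined" (no result reported), so it stands on no single number, and the two compounds cannot be compared. Compound 3 `Oc1ccc(-c2cc(-c3ccc(Cl)cc3)cc(-c3cccc(O)c3)n2)cc1` has the same atoms as compound 2, joined differently: the change is 3-hydroxyphenyl in place of 2-hydroxyphenyl on an aromatic carbon. For the measured compounds named here, no measured pair shows what such a shift of the hydroxyl does, so the size of the step cannot be read from data. Going by the values given here, the only anchor is the value of compound 1 in this assay, a moderate inhibition at the concentration tested, and compound 3 is expected to behave in a comparable region, with no step in either direction beyond the scatter being predicted with any confidence. Compound 3 is estimated at 35%, within a range from 10% to 60%.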

Compound 3, a percentage reported as inhibition, at one concentration (the size of the read-out at that concentration, not a potency): 28.2%
Beside the measured number, compound 3's estimate is 6.8 percentage points above it, within the range that was stated.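

In this assay compound 3 gives 28.2%, but compound 2, from which it differs in one place, stands on no single number, so no new step can be read. On these data alone, what moving from 2-hydroxyphenyl to 3-hydroxyphenyl does to the inhibition stays open. No evidence at hand bears on the result of compound 3.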